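The compounds below may be only part of what the source reports. "The series", "measured", "known", "first", "only" and "open" are said of these compounds alone.

Three compounds built on a shared core carrying a triazole whose aromatic nitrogen bears an aryl group have been examined in a functional assay on MCF7 cells (Homo sapiens) for antiproliferative activity, read by MTT assay, with a stated time of 48 h; a higher number here means a weaker inhibitor, a lower number a stronger inhibitor. Compound 1 `N#CC1=C(N)Oc2c(N)cc3nc4ccccc4nc3c2C12C(=O)N(Cc1cnnn1-c1ccc(Cl)cc1)c1ccccc12` carries a 4-chlorophenyl on that nitrogen. In this assay compound 1 gives > 50000 nM, which is a limit of the assay rather than a number. Compound 2 `N#CC1=C(N)Oc2c(N)cc3nc4ccccc4nc3c2C12C(=O)N(Cc1cnnn1-c1cccc(Br)c1)c1ccccc12` carries a 3-bromophenyl instead. In this assay compound 2 gives > 50000 nM, again a limit. For the measured compounds named here, compound 3 `N#CC1=C(N)Oc2c(N)cc3nc4ccccc4nc3c2C12C(=O)N(Cc1cnnn1-c1cc(Cl)ccc1Cl)c1ccccc12` carries a 2,5-dichlorophenyl, and in this assay compound 3 gives 33200 nM, the only number among the three; the other two values sit at the limit of > 50000 nM in this assay, at which 2 of the 3 values shown sit. The step that the two limits leave unreadable from compound 1 to compound 2 cannot be read. The steps of an at least 1.5-fold lower number from compound 1 to compound 3 (0.17 log units; that floor lies within the scatter) and an at least 1.5-fold lower number from compound 2 to compound 3 (0.17 log units; that floor lies within the scatter) are floors only, and the floor itself lies within the scatter.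

Compound 4 `COc1ccc(OC)c(-n2nncc2CN2C(=O)C3(C(C#N)=C(N)Oc4c(N)cc5nc6ccccc6nc5c43)c3ccccc32)c1` differs from compound 3 in one place: 2,5-dimethoxyphenyl in place of 2,5-dichlorophenyl on an aromatic nitrogen. Going by the values given here, no measured step exchanges a halogenated aryl for a methoxylated one, so the two floor steps into compound 3 give only a weak lean. A step of a 1.2-fold higher number from compound 3 to compound 4 (0.08 log units; within the scatter) is therefore expected, not clearly beyond the scatter in either direction. Compound 4 is estimated at 40000 nM, within a range from 12000 nM to 100000 nM.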

Compound 4, half-maximal inhibitory concentration: 28100 nM
For compound 4 the middle estimate is 1.4-fold (0.15 log units) above the measured one; low and high end bracket the measured number.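

In this assay, the only step shown that exchanges a halogenated aryl for a methoxylated one on the aromatic nitrogen gives a 1.2-fold lower number from compound 3 to compound 4 (0.07 log units; within the scatter), so the 2,5-dimethoxyphenyl and the 2,5-dichlorophenyl cannot be told apart here. Chlorine and methoxy substituents in the same two places thus read alike, and compound 4 joins compound 3 as a second compound with a true number rather than a limit, while the 4-chlorophenyl of compound 1 and the 3-bromophenyl of compound 2 give none. Against those two, the result gives an at least 1.7-fold lower number from compound 2 to compound 4 (0.25 log units; that floor lies within the scatter) and an at least 1.7-fold lower number from compound 1 to compound 4 (0.25 log units; that floor lies within the scatter), and both remain floors that do not separate the compounds because two of the values are limits, not numbers: the limit of > 50000 nM in this assay, at which 2 of the 4 values shown sit.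

On these data alone, whether an amine or a carboxylic acid on this phenyl ring, or a longer chain in place of the methoxy groups, would move the number beyond the scatter stays open. So does what a plain phenyl or a single methoxy group would give on this nitrogen, and how large the steps from compound 1 and compound 2 truly are.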